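A few compounds are considered here, and "the series" means these few. Any claim that something is new, unique, unknown or untested is made for them only; others in the source may bear on it.

Measured compounds in an ADME assay for permeability, using PAMPA, with a stated time of 4 h, tested at 10 uM; a lower number here means that the compound crosses the layer more slowly, a higher number that the compound crosses the layer faster:

- compound 1, `O=C(CCCCN1CCCCC1)Nc1cc(-c2ccc(Br)cc2)n[nH]1`: compound 1 gives > 10 10^-6 cm/s, which is a limit of this assay and not a number.
- compound 2, `COc1ccc(-c2n[nH]c(NC(=O)CCCCN3CCCN(C(C)=O)CC3)c2C)cc1`: compound 2 gives 2 10^-6 cm/s.
- compound 3, `O=C(CCCCN1CCCCC1)Nc1cc(-c2ccc(C(F)(F)F)cc2)n[nH]1`: compound 3 gives > 10 10^-6 cm/s, again a limit of this assay.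

Within the data shown here, compound 1 therefore stands only at a limit in this assay, and of the three values shown two sit at that limit (the limit of > 10 10^-6 cm/s in this assay, at which 2 of the 3 values shown sit); the single numeric value belongs to compound 2, whose core carries a different substitution pattern and a different amine, so no step to compound 1 is computed for it.

Among the measured compounds shown here, the one measured step that changes the same aromatic group on the shared core is a step that the two limits leave unreadable from compound 1 to compound 3. Both of its ends sit at the limit. Its size cannot be read.

Compound 4, `COc1cccc(-c2cc(NC(=O)CCCCN3CCCCC3)[nH]n2)c1`, differs from compound 1 by 3-methoxyphenyl in place of 4-bromophenyl on an aromatic carbon. For the measured compounds named here, no measured step reports a readable size for a change at this position, and the only comparable one stays at the limit. The expectation for this assay is that compound 4 behaves like compound 1, with a step that the limit leaves unreadable from compound 1 to compound 4 estimated as none beyond the scatter. Compound 4 is thus expected to give about 12 10^-6 cm/s, within roughly 6 10^-6 cm/s to 25 10^-6 cm/s, most likely again reported as a limit.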

Compound 4, apparent permeability: > 10 10^-6 cm/s
Compound 4: a limit, no number; the forecaster's own chance of this, stated with the estimate: 65%; the middle value is on the limit's open side.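

In this assay compound 4 gives > 10 10^-6 cm/s, a limit and not a number. No step size can be read between compound 1 and compound 4, because both sit at a limit: the limit of > 10 10^-6 cm/s in this assay, at which 3 of the 4 values shown sit.

The compounds shown leave open whether changing the aromatic group on the shared core alters apparent permeability among compound 1, compound 3 and compound 4.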